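The compounds below may be only part of what the source reports. "The series", "measured", "known", "first", "only" and "open" are said of these compounds alone.

Compound 1 `Nc1nc(O)nc2c1nc(O)n2Cc1ccccc1`, compound 2 `CCOc1nc(N)c2nc(O)n(Cc3ccccc3)c2n1` and compound 3 `CCNc1nc(N)c2nc(O)n(Cc3ccccc3)c2n1` share one core. In a functional assay (spleen, spleen) for activation, with Mus musculus as the target (on this read-out lower numbers stand for an effect already at smaller amounts and higher numbers for an effect only at larger amounts of compound), compound 1 gives 0.1 uM, compound 2 gives 0.1 uM and compound 3 gives 1 uM, the highest of the three numbers. Two steps describe this set: no change at the digits printed from compound 1 to compound 2 (within the scatter), and a 10-fold higher number from compound 2 to compound 3 (1.00 log units; beyond the scatter). The step to compound 4 `COc1nc(N)c2nc(O)n(Cc3ccccc3)c2n1` is methoxy in place of ethylamino on an aromatic carbon. It runs the second step backwards, ethylamino giving way to an oxygen-bound group, while the first step suggests that the length of the chain on that oxygen hardly matters. A fall of about the size seen in that second step is therefore expected, a 10-fold lower number from compound 3 to compound 4 (1.00 log units; beyond the scatter). Compound 4 is estimated at 0.1 uM, between 0.03 uM and 0.5 uM.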

Compound 4, minimum effective concentration: 0.1 uM
For compound 4 middle estimate and measured number coincide at the digits printed; measured number inside the range.
By their numbers in this assay, from the lowest: compounds 1, 2 and 4 (each within the scatter of the next); then compound 3.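

In this assay, methoxy at this position gives the same picture as ethoxy (no change at the digits printed from compound 2 to compound 4 (within the scatter)) and as hydroxy (no change at the digits printed from compound 1 to compound 4 (within the scatter)). Across these three compounds, then, the oxygen can carry no chain, a methyl or an ethyl without a difference beyond the scatter. Ethylamino alone stands apart, and a second oxygen-bound group now shows the same gap (a 10-fold lower number from compound 3 to compound 4 (1.00 log units; beyond the scatter)). As far as these compounds go, whether a plain amine or a longer chain such as butoxy would fall with the oxygen-bound groups or with ethylamino stays open. Nothing available explains the gap.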